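Swapping Butoxyphenyl for Methylphenyl on a Hydrazide

The compounds below may be only part of what the source reports. "The series", "measured", "known", "first", "only" and "open" are said of these compounds alone.

In a functional assay on OVCAR-3 cells (Homo sapiens) for antiproliferative activity, read by MTT assay, with a stated time of 24 h (on this read-out higher numbers stand for weaker inhibition and lower numbers for stronger inhibition), compound 1 `CCCCOc1ccc(C(=O)NNC(=O)c2ccc(NS(=O)(=O)c3cnc(O)nc3O)cc2)cc1` gives 12800 nM. Compound 2 `Cc1ccccc1C(=O)NNC(=O)c1ccc(NS(=O)(=O)c2cnc(O)nc2O)cc1` reaches only a limit in this assay, > 20000 nM. Compound 2 differs from compound 1 by 2-methylphenyl in place of 4-butoxyphenyl on a carbonyl carbon, and this change produces an at least 1.5-fold higher number from compound 1 to compound 2 (0.19 log units; that floor lies within the scatter), a floor set because of the limit of > 20000 nM in this assay, at which 1 of the 3 values shown sits. Compound 3 `CCCCOc1ccc(C(=O)NNC(=O)c2cccc(NS(=O)(=O)c3cnc(O)nc3O)c2)cc1` has a core that differs from that of compound 1 in a way not broken down here. In this assay compound 3 gives 9200 nM. Compound 4 `Cc1ccccc1C(=O)NNC(=O)c1cccc(NS(=O)(=O)c2cnc(O)nc2O)c1` carries the same change as before, (2-methylphenyl in place of 4-butoxyphenyl on a carbonyl carbon). For compound 4 the estimated step is a 2.2-fold higher number from compound 3 to compound 4 (0.34 log units; beyond the scatter), expected to resemble an at least 1.5-fold higher number from compound 1 to compound 2 (0.19 log units; that floor lies within the scatter) seen from compound 1 to compound 2. On that basis compound 4 is expected to give about 20000 nM in this assay, plausibly between 9000 nM and 50000 nM, with a real chance that only a limit is reported.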

Compound 4, half-maximal inhibitory concentration: > 20000 nM
Compound 4: no number, only a limit (the forecaster's own chance of this, stated with the estimate: 50%); the middle value lies on the limit itself.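

In this assay, putting 2-methylphenyl in place of 4-butoxyphenyl on the core of compound 3 gives an at least 2.1-fold higher number from compound 3 to compound 4 (0.33 log units; beyond the scatter). Compound 4 gives > 20000 nM, which is a limit and not a number. The second core thus shows a rise beyond the scatter and does not contradict the floor seen on the first core, but this does not show that the change has the same size on both cores: the same change on two cores in this assay, an at least 1.5-fold higher number (0.19 log units; that floor lies within the scatter) from compound 1 to compound 2 and an at least 2.1-fold higher number (0.33 log units; beyond the scatter) from compound 3 to compound 4; the limit leaves it open whether they differ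

The compounds shown leave open whether a 4-methoxyphenyl or a 4-aminophenyl group on the same carbonyl carbon would behave more like 4-butoxyphenyl or more like 2-methylphenyl. They also leave open whether a longer chain than butoxy would give a lower number in this assay.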